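The compounds below may be only part of what the source reports. "The series", "measured", "known", "first", "only" and "open" are said of these compounds alone.

Three compounds share one core and differ only in the aromatic ring attached to it. In an assay (Rattus norvegicus) for inhibition of Fatty-acid amide hydrolase 1 (Homo sapiens) (a lower number here means a stronger inhibitor, a higher number a weaker inhibitor), compound 1 `Cc1cccnc1-c1cnc(C(=O)CCCCCCc2ccccc2)o1` gives 15 nM. Compound 2 `Cc1ccnc(-c2cnc(C(=O)CCCCCCc3ccccc3)o2)c1` gives 0.6 nM, and compound 3 `NC(=O)c1ccc(-c2cnc(C(=O)CCCCCCc3ccccc3)o2)nc1` gives 1.2 nM, which places compound 3 second highest of the three, close to compound 2 and far from compound 1. Compound 4 `O=C(CCCCCCc1ccccc1)c1ncc(-c2ccncn2)o1` carries pyrimidin-4-yl in place of 5-carbamoylpyridin-2-yl on an aromatic carbon. The same position was changed in the measured steps: a 25-fold lower number from compound 1 to compound 2 (1.40 log units; beyond the scatter) and a 13-fold lower number from compound 1 to compound 3 (1.10 log units; beyond the scatter), while a 2.0-fold higher number from compound 2 to compound 3 (0.30 log units; within the scatter). Changes at this ring can therefore be large, yet two different rings in place of the 3-methylpyridin-2-yl of compound 1 gave nearby numbers in compounds 2 and 3. Compound 4 is thus expected to give 3 nM, within 0.6 nM to 15 nM, a step of a 2.5-fold higher number from compound 3 to compound 4 (0.40 log units; beyond the scatter).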

Compound 4, inhibition constant: 2.3 nM
Compound 4: middle estimate off by 1.3-fold (0.12 log units), on the high side, within the range that was stated.
By their numbers in this assay, from the lowest: compounds 2, 3 and 4 (each within the scatter of the next, the first and the last beyond it); then compound 1.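

The pyrimidin-4-yl ring has no hydrogen-bond donor, unlike 5-carbamoylpyridin-2-yl, yet a 1.9-fold higher number from compound 3 to compound 4 (0.28 log units; within the scatter) stays within the scatter, so a low number here does not require that amide group. A ring with two hetero atoms also keeps most of the gain over the 3-methylpyridin-2-yl ring, with a 6.5-fold lower number from compound 1 to compound 4 (0.81 log units; beyond the scatter) and still a 3.8-fold higher number from compound 2 to compound 4 (0.58 log units; beyond the scatter) to show that the 4-methylpyridin-2-yl ring keeps a measurable lead.

As far as these compounds go, whether an amine or a carboxylic acid on this ring would hold the number remains open. Nothing available explains these steps.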